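A few compounds are considered here, and "the series" means these few. Any claim that something is new, unique, unknown or untested is made for them only; others in the source may bear on it.

Measured compounds:

Compound 1, `O=C(NC1CCN(c2ncnc3[nH]ncc23)CC1)c1ccc(F)cc1`, gives 4540 nM in an assay on isolated protein for inhibition of serine/threonine-protein kinase PAK 1 (Homo sapiens), read by ADP-Glo, with a stated time of 40 min; on this read-out higher numbers stand for weaker inhibition and lower numbers for stronger inhibition.

Compound 2, `O=C(NC1CCN(c2ncnc3[nH]ncc23)CC1)c1ccc(C(F)(F)F)cc1`, gives 5740 nM in this assay.

Compound 3, `O=C(NC1CCN(c2ncnc3[nH]ncc23)CC1)c1cccc(C(F)(F)F)c1`, gives 2510 nM in this assay.

All three share one core and differ only in the substituted phenyl ring attached to the amide carbonyl. Going by the values given here, compound 1 sits in the middle of the three numbers, but none of the gaps reaches beyond the usual scatter: the step from compound 1 to compound 2, a 1.3-fold higher number from compound 1 to compound 2 (0.10 log units; within the scatter), is the only single-point change measured, and the number for compound 3 also lies within the scatter of compound 1. So far, swapping one halogen-type substituent for another on this phenyl ring has not moved this assay in a way that can be told from noise.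

Compound 4, `O=C(NC1CCN(c2ncnc3[nH]ncc23)CC1)c1ccccc1Cl`, differs from compound 1 by 2-chlorophenyl in place of 4-fluorophenyl on a carbonyl carbon. Among the compounds with values here, the only comparable measured step is that from compound 1 to compound 2, which stayed within the scatter, so no step beyond the scatter is expected here either. The expected step from compound 1 to compound 4 is estimated as a 1.0-fold lower number from compound 1 to compound 4 (0.00 log units; within the scatter). For compound 4 the estimated value in this assay is 4500 nM, with a range from 1500 nM to 14000 nM.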

Compound 4, half-maximal inhibitory concentration: 5240 nM
Compound 4: middle estimate off by 1.2-fold (0.07 log units), on the low side; the range from low to high includes it.
By their numbers in this assay, from the lowest: compounds 3, 1, 4 and 2 (each within the scatter of the next, the first and the last beyond it).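

Replacing 4-fluorophenyl with 2-chlorophenyl on the carbonyl carbon alters both the halogen and its place on the ring in a single step, which the earlier step between compounds did not do. Even so, in this assay the result is a 1.2-fold higher number from compound 1 to compound 4 (0.06 log units; within the scatter), so this double alteration is as hard to tell from noise as the earlier swap of substituents. No supporting measurement bears on this result, and the size of the step cannot separate the role of the halogen from the role of its place on the ring.

Every group on this carbonyl carbon so far is a phenyl ring bearing fluorine or chlorine. Going by these compounds, it remains open whether an amine or a carboxylic acid on that ring, or a longer chain in place of the ring, would give a step beyond the scatter.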